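Replacing the 4-methylpiperazin-1-yl group of compound 2 with hydrogen

The source may report more compounds than this note shows. Statements on the series, on what has been measured and on what is new or still open speak of the compounds shown alone.

Measured so far in an ADME assay on HepG2 cells (Homo sapiens) for inhibition, read by fluorescence and resazurin assay, with a stated time of 72 h (on this read-out higher numbers stand for weaker inhibition and lower numbers for stronger inhibition), of the series
Compound 1 `NS(=O)(=O)c1cccc(Nc2nccc(Nc3ccc4nc[nH]c4c3)n2)c1` gives > 25000 nM as a limit
Compound 2 `Cc1cc(Nc2nccc(Nc3ccc4nc[nH]c4c3)n2)ccc1N1CCN(C)CC1` gives 15000 nM as a number

Going by the values given here, compound 2 (15000 nM) holds the only actual number in this assay so far. Among the compounds with values here, the one other value, that of compound 1, is a limit. In compound 3 `Cc1cccc(Nc2nccc(Nc3ccc4nc[nH]c4c3)n2)c1` hydrogen stands in place of 4-methylpiperazin-1-yl on an aromatic carbon, ortho to a methyl group (hydrogen in place of 4-methylpiperazin-1-yl on an aromatic carbon). Within the data shown here, no measured step shows what such a change does. The expectation leans on compound 1, whose > 25000 nM is a limit. A small step toward weaker inhibition is expected (a 1.7-fold higher number from compound 2 to compound 3 (0.22 log units; within the scatter)), possibly no larger than the usual scatter. Compound 3 is estimated at 25000 nM (expected range 10000 nM to 55000 nM), and it may also come back as a limit alone.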

Compound 3, half-maximal inhibitory concentration: 20000 nM
For compound 3 the middle estimate is 1.3-fold (0.10 log units) above the measured one; low and high end bracket the measured number.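

In this assay, hydrogen in place of 4-methylpiperazin-1-yl on this aromatic carbon, ortho to a methyl group, gives a 1.3-fold higher number from compound 2 to compound 3 (0.12 log units; within the scatter), so the read-out shows no measurable dependence on that large group at this position. Methyl in place of sulfamoyl gives an at least 1.2-fold lower number from compound 1 to compound 3 (0.09 log units; that floor lies within the scatter), and this figure is only a floor for the step. The true size of that step stays unknown because compound 1 has a limit and not a number: the limit of > 25000 nM in this assay, at which 1 of the 3 values shown sits.

The compounds shown leave open whether a small amine or a carboxylic acid on this aromatic carbon would give a step beyond the scatter. They also leave open whether a longer chain in place of the methyl group would change the number in this assay.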